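The source may report more compounds than this note shows. Statements on the series, on what has been measured and on what is new or still open speak of the compounds shown alone.

Compound 1 `Cc1cc(S(=O)(=O)/N=C(\N)N/N=C/C#Cc2ccccc2)c(SCc2ccccc2)cc1Cl` gives 8000 nM in a functional assay on HCT-116 cells (Homo sapiens) for antiproliferative activity, read by MTT assay, with a stated time of 72 h; on this read-out lower numbers stand for stronger inhibition and higher numbers for weaker inhibition.
Compound 2 `Cc1cc(S(=O)(=O)/N=C(\N)N/N=C/C#Cc2ccccc2)c(SCc2ccccc2C)cc1Cl` gives 19000 nM.
Compound 3 `Cc1cc(S(=O)(=O)/N=C(\N)N/N=C/C#Cc2ccccc2)c(SCc2ccccc2C(F)(F)F)cc1Cl` gives 18000 nM.

Among these three numbers compound 3 stands second highest; its gap to compound 2 lies within the scatter, while its gap to compound 1 lies beyond it. Compound 4 `Cc1cc(S(=O)(=O)/N=C(\N)N/N=C/C#Cc2ccccc2)c(SCc2ccc(C(F)(F)F)cc2)cc1Cl` differs from compound 3 by 4-(trifluoromethyl)phenyl in place of 2-(trifluoromethyl)phenyl on a saturated chain carbon bound to a sulfur. Among the compounds with values here, no measured step moves a substituent around this ring. The steps that touch the ring are a 2.3-fold higher number from compound 1 to compound 3 (0.35 log units; beyond the scatter) and a 2.4-fold higher number from compound 1 to compound 2 (0.38 log units; beyond the scatter), both modest, and a 1.1-fold lower number from compound 2 to compound 3 (0.02 log units; within the scatter), within the scatter: the two substituents tried so far raised the number to a similar extent, but nothing shows what another placement does. A step of a 1.4-fold lower number from compound 3 to compound 4 (0.14 log units; within the scatter) is therefore expected for compound 4, small and uncertain in direction. Compound 4 is estimated at 13000 nM, within 5000 nM to 32000 nM.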

Compound 4, half-maximal inhibitory concentration: 70000 nM
For compound 4 the middle estimate is 5.4-fold (0.73 log units) below the measured one; the whole stated range lies below it.
By their numbers in this assay, from the lowest: compound 1; then compounds 3 and 2 (each within the scatter of the next); then compound 4.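

Moving the trifluoromethyl group around this ring changes the result in this assay: 4-(trifluoromethyl)phenyl in place of 2-(trifluoromethyl)phenyl gives a 3.9-fold higher number from compound 3 to compound 4 (0.59 log units; beyond the scatter), whereas exchanging methyl for trifluoromethyl gave no change beyond the scatter. Against the methyl analogue the same group gives a 3.7-fold higher number from compound 2 to compound 4 (0.57 log units; beyond the scatter), and against the bare ring an 8.8-fold higher number from compound 1 to compound 4 (0.94 log units; beyond the scatter), so compound 1 keeps the lowest number of the four. Nothing available explains this effect of placement. As far as these compounds go, whether placement matters equally for methyl remains open, as does the outcome with an amine or a carboxylic acid on this ring.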